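The compounds below may be only part of what the source reports. "The series", "measured", "known", "first", "only" and "open" are said of these compounds alone.

In an assay on HEK293 cells for binding affinity to D(4) dopamine receptor (Homo sapiens), read by radioligand binding (a higher number here means a weaker inhibitor, a lower number a stronger inhibitor), compound 1 `COc1ccccc1N1CCN(CCCCNC(=O)C(C)(C)C)CC1` gives 12.6 nM, and compound 2 `CC(C)(C)C(=O)NCCCCN1CCN(c2ccccc2Cl)CC1` gives 79.4 nM, the higher of the two numbers. Among the compounds with values here, the only measured step, a 6.3-fold higher number from compound 1 to compound 2 (0.80 log units; beyond the scatter), concerns a different change and does not bear directly on what follows. Compound 3 `CC(C)(C)C(=O)NCCCCN1CCN(c2ccc(Cl)cc2)CC1` differs from compound 2 by 4-chlorophenyl in place of 2-chlorophenyl on an amine nitrogen in a ring. Within the data shown here, no measured pair shows what this rearrangement does, so the direction rests on no data. Compound 3 is therefore only tentatively expected to give a somewhat weaker number, estimated at 250 nM, within 50 nM to 1500 nM. That expected shift amounts to a 3.1-fold higher number from compound 2 to compound 3 (0.50 log units; beyond the scatter).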

Compound 3, inhibition constant: 12.6 nM
Beside the measured number, compound 3's estimate is 20-fold (1.30 log units) above it, and the stated range ends above it.
By their numbers in this assay, from the lowest: compounds 1 and 3 (each within the scatter of the next); then compound 2.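

Moving the chlorine, from 2-chlorophenyl to 4-chlorophenyl on the same ring nitrogen, matters in this assay, giving a 6.3-fold lower number from compound 2 to compound 3 (0.80 log units; beyond the scatter). The 4-chlorophenyl group also stands level with the 2-methoxyphenyl group, with no change at the digits printed from compound 1 to compound 3 (within the scatter), so among these compounds a chlorine on this ring does not by itself bring the higher number; its placement counts. Nothing measured here explains this effect of placement. Still open, on these data alone, is how a plain phenyl group or a fluorophenyl group would read on the same ring nitrogen. Also open, as far as these compounds go, is whether this rearrangement gives a similar step in a molecule with a longer chain.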